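Swapping the aryl ring on the saturated ring carbon

The source may hold more compounds than are shown below. What is called first, only, known or untested is meant among the compounds shown, and "the series" means these compounds.

Of the compounds shown here, three sharing one core have been tested in a functional assay on the whole organism (artery, strain albino) with Rattus norvegicus as the target, with a stated time of 120 min, at a dose of 10 mg/kg by the oral route; a higher number here means more inhibition at the dose given (going by the name of the read-out), a lower number less inhibition. Compound 1 `CC1=C(C(=O)Nc2ccc([N+](=O)[O-])cc2)C(c2ccc(Br)cc2)N=C(SCc2ccccc2)N1` gives 13.4%. Compound 2 `CC1=C(C(=O)Nc2ccc([N+](=O)[O-])cc2)C(c2ccc(Br)cc2)N=C(SCc2cccc(Cl)c2)N1` gives 6.7%, and compound 3 `CC1=C(C(=O)Nc2ccc([N+](=O)[O-])cc2)C(c2ccc(Br)cc2)N=C(SCc2ccc(F)cc2)N1` gives 12.9%. Compound 1 thus holds the highest of the three numbers, yet both gaps below it fall within the scatter: a number 6.7 percentage points lower from compound 1 to compound 2 (within the scatter) and a number 0.5 percentage points lower from compound 1 to compound 3 (within the scatter). Likewise, a number 6.2 percentage points higher from compound 2 to compound 3 (within the scatter). Every one of these steps alters only the benzylsulfanyl group, not the saturated ring carbon.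

Compound 4 `CC1=C(C(=O)Nc2ccc([N+](=O)[O-])cc2)C(c2cccc([N+](=O)[O-])c2)N=C(SCc2ccccc2)N1` changes a different part of the core: 3-nitrophenyl in place of 4-bromophenyl on a saturated ring carbon. Among the compounds with values here, no measured step touches this position, so none bears directly on the change, and the only guide is that all three steps that were measured stayed within the scatter. The expectation is therefore a step of no real size, a number 0.4 percentage points lower from compound 1 to compound 4 (within the scatter). Compound 4 is expected to give about 13% in this assay, somewhere between 3% and 25%.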

Compound 4, a percentage reported as inhibition, in the whole organism at one dose (the size of the read-out at that dose, not a potency): 10.3%
For compound 4 the middle estimate is 2.7 percentage points above the measured one; the range from low to high includes it.
By their numbers in this assay, from the lowest: compounds 2, 4, 3 and 1 (each within the scatter of the next).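

At the saturated ring carbon, 3-nitrophenyl in place of 4-bromophenyl in this assay gives a number 3.1 percentage points lower from compound 1 to compound 4 (within the scatter). Within the data shown here, this is the first look at this position, and like the changes to the benzylsulfanyl group, this change produces no step beyond the scatter, even though the entering group carries hydrogen-bond acceptors that the leaving group lacks. No measured evidence offers an explanation for the size of this step.

This one step changes both the substituent on the aryl ring and its place on that ring, and the two effects cannot be told apart here. Going by these compounds, it remains open whether an amine or a carboxylic acid on this aryl ring, or a saturated alkyl chain in place of the ring, would move the number beyond the scatter.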